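The source may hold more compounds than are shown below. What is called first, only, known or untested is meant among the compounds shown, and "the series" means these compounds.

Compound 1: `O=[N+]([O-])c1ccc(-c2scc3c2CCOC32CCN(Cc3ccccc3)CC2)cc1` — 1.7 nM
Compound 2: `COC1Cc2cscc2C2(CCN(Cc3ccccc3)CC2)O1` — 0.22 nM

Of the compounds shown here, two have been measured in an assay on membranes from brain for displacement of a labelled ligand from Sigma non-opioid intracellular receptor 1 (Cavia porcellus), read by scintillation counting, with a stated time of 120 min; a lower number here means a stronger inhibitor, a higher number a weaker inhibitor. Compound 1, with the structure `O=[N+]([O-])c1ccc(-c2scc3c2CCOC32CCN(Cc3ccccc3)CC2)cc1`, gives 1.7 nM. Compound 2, with the structure `COC1Cc2cscc2C2(CCN(Cc3ccccc3)CC2)O1`, gives 0.22 nM. Compound 2 thus stands at the lower of the two numbers, and its gap to compound 1 lies beyond the usual scatter of repeated measurements. Going by the values given here, the two compounds differ in more than one place, so no single step links them.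

Compound 3, with the structure `COc1ccc(-c2scc3c2CC(OC)OC32CCN(Cc3ccccc3)CC2)cc1`, has not yet been measured. It arises from compound 2 by one change: 4-methoxyphenyl in place of hydrogen on an aromatic carbon. Among the compounds with values here, no measured pair shows exactly this change. Within the data shown here, the only hint comes from compound 1, which also carries an aryl group on the shared core and gives a higher number than compound 2 in this assay. For compound 3 a modest rise in the number is therefore expected, the estimated step being a 4.5-fold higher number from compound 2 to compound 3 (0.66 log units; beyond the scatter), which is judged likely to stay smaller than the gap just described. For compound 3 the expected value is 1 nM, with a range from 0.3 nM to 4 nM.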

Compound 3, inhibition constant: 2.2 nM
Beside the measured number, compound 3's estimate is 2.2-fold (0.34 log units) below it, within the range that was stated.
By their numbers in this assay, from the lowest: compound 2; then compounds 1 and 3 (each within the scatter of the next).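

Placing 4-methoxyphenyl in place of hydrogen on the aromatic carbon next to the ring sulfur gives a 10-fold higher number from compound 2 to compound 3 (1.00 log units; beyond the scatter) in this assay and provides the first direct reading of a change at this position, since the two compounds differ in that one place alone. The change therefore has a real cost, but it does not abolish binding: compound 3 gives 2.2 nM and remains a nanomolar inhibitor even with a whole aromatic ring added at this carbon. No measurement here explains why the number rises.

A single substitution cannot show whether the rise belongs to the six-membered aromatic ring itself, to the methoxy group on it, or to any group larger than hydrogen at this carbon. The compounds shown also leave open how much smaller or differently built groups at the same position, such as a methyl group, a chain ending in an amine, or a carboxylic acid, would shift the number.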